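This account rests on a few compounds, and the source may have more. Where it says the series, first, only, none or still open, it means among the compounds named here.

Series notes. Two compounds carry numbers in a functional assay on the whole organism for inhibition, with Mus musculus as the target, in the writhing test, with a stated time of 1 h, at a dose of 10 mg/kg by the oral route; on this read-out higher numbers stand for more inhibition at the one dose given (going by the name of the read-out) and lower numbers for less inhibition. Compound 1 `CC(C)(C)c1ccc(C(CCN2CCN(c3ccccc3)CC2)OC(N)=O)cc1` gives 62% in this assay. Compound 2 `COc1ccc(N2CCN(CCC(OC(N)=O)c3ccccc3)CC2)c(OC)c1` gives 19% in this assay. For the measured compounds named here, compound 1 therefore stands highest of the two numbers known; compound 2 is the nearest, and its number lies well below, beyond the usual scatter. Going by the values given here, no pair of the measured compounds differs in one place only, so the two numbers show a gap but no single isolated change behind it.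

Compound 3 `COc1ccc(C(CCN2CCN(c3ccccc3)CC2)OC(N)=O)cc1` has not been measured in this assay. It differs from compound 1 in one place: methoxy in place of tert-butyl on an aromatic carbon. The change sits on an aromatic carbon of a six-membered aromatic ring of carbon only, para to a large group. Among the compounds with values here, no measured step of this kind is available, so the direction cannot be read from a neighbour; compound 2 carries a different pattern of groups and also differs elsewhere, so its number is only a loose pointer downward. A moderate drop is expected, the estimated step being a number 22 percentage points lower from compound 1 to compound 3 (beyond the scatter). Compound 3 is accordingly expected to give 40% in this assay, within a range from 15% to 65%.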

Compound 3, a percentage reported as inhibition, in the whole organism at one dose (the size of the read-out at that dose, not a potency): 43%
The estimate for compound 3 lay 3 percentage points below the measured number; measured number inside the range.
By their numbers in this assay, from the lowest: compound 2; then compound 3; then compound 1.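

In this assay, for the compounds shown here, the replacement of tert-butyl by methoxy on the aromatic carbon para to a large group comes out as a number 19 percentage points lower from compound 1 to compound 3 (beyond the scatter) and is the first change confined to one place. This position is therefore not silent: with the rest of the core held fixed, a change here alone moves the inhibition at the one dose by more than the usual scatter, yet a clear part of the read-out remains, as compound 3 still gives 43% at that dose. Going by these compounds alone, no measurement on these compounds speaks to the origin of this step.

A single step cannot separate the drop from heavy atoms to the hydrogen-bond acceptor that enters with methoxy, since both differences travel together in this one change. Also open, on these data alone, is where other groups at this position, such as isopropyl, trifluoromethyl, chlorine or a plain hydrogen, would fall relative to tert-butyl and methoxy, and whether the same step would hold with other substituents elsewhere on the core.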